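Carbamate Swap on a Shared Core Against Leukemia Cells

The source may hold more compounds than are shown below. What is called first, only, known or untested is meant among the compounds shown, and "the series" means these compounds.

Three compounds share one core and differ only in the group attached through a carbamate. Compound 1 `C=C1C(=O)O[C@H]2[C@H]1CC/C(COC(=O)Nc1n[nH]c(SC)n1)=C\CC[C@@]1(C)O[C@@H]21` carries a methylthio-triazolyl amino group there, but in a functional assay on K562 cells (Homo sapiens) for inhibition (on this read-out higher numbers stand for weaker inhibition of growth and lower numbers for stronger inhibition of growth), compound 1 gives "not determined" (no result reported). Among the compounds with values here, compound 2 `C=C1C(=O)O[C@H]2[C@H]1CC/C(COC(=O)N1CCC(F)(F)CC1)=C\CC[C@@]1(C)O[C@@H]21` carries a 4,4-difluoropiperidin-1-yl group, and in this assay compound 2 gives 3450 nM, the only number available here. Compound 3 `C=C1C(=O)O[C@H]2[C@H]1CC/C(COC(=O)NCCN1CCCC1)=C\CC[C@@]1(C)O[C@@H]21` is the unmeasured partner of compound 2; the change between them is (2-(pyrrolidin-1-yl)ethyl)amino in place of 4,4-difluoropiperidin-1-yl on a carbonyl carbon. Within the data shown here, with no measured pair of this kind to lean on, the size of the step cannot be read from other compounds. The step from compound 2 to compound 3 is expected to bring somewhat stronger inhibition of growth, about a 1.9-fold lower number from compound 2 to compound 3 (0.28 log units; within the scatter), though the uncertainty covers no change at all. Compound 3 is therefore estimated at 1800 nM, with a likely range from 500 nM to 6000 nM.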

Compound 3, concentration for 50% growth inhibition: 3260 nM
Compound 3: the middle estimate sits 1.8-fold (0.26 log units) below what was measured; low and high end bracket the measured number.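

At the carbonyl carbon in this assay, putting (2-(pyrrolidin-1-yl)ethyl)amino in place of 4,4-difluoropiperidin-1-yl gives a 1.1-fold lower number from compound 2 to compound 3 (0.02 log units; within the scatter), so the read-out does not separate these two groups. The two differ clearly in structure: the number of heavy atoms stays the same, but a six-membered ring gives way to a five-membered one, the fluorine atoms leave, and a hydrogen-bond donor enters, yet growth inhibition shows no change beyond the scatter. No measurement offered here accounts for why the two groups read alike. A single readable step cannot show whether a morpholine ring or a carboxylic acid on the same carbonyl carbon would also leave the number in place. It also leaves open what a longer chain in the (2-(pyrrolidin-1-yl)ethyl)amino group would do.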